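This account rests on a few compounds, and the source may have more. Where it says the series, first, only, none or still open, it means among the compounds named here.

Measured so far:
compound 1 `C[C@H]1CC[C@@H](c2nc3cccc(Cl)c3c(=O)n2N2CCOCC2)N1c1nc(N)nc2[nH]cnc12`: 600 nM
compound 2 `N#Cc1c(N)nc(N)nc1N1[C@H](c2nc3cccc(Cl)c3c(=O)n2N2CCOCC2)C[C@@H]2CCCC[C@@H]21`: 1040 nM

In a functional assay on SUD4 cells (Homo sapiens) for inhibition, read by MTT assay, with a stated time of 72 h (a higher number here means a weaker inhibitor, a lower number a stronger inhibitor), compound 1 gives 600 nM, the lowest of the two numbers; compound 2 gives 1040 nM, and the gap between them lies within the scatter, so neither is set apart. Compound 3 `C[C@H]1CC[C@@H](c2nc3cccc(Cl)c3c(=O)n2N2CCOCC2)N1c1nc(N)nc(N)c1C#N` is not yet measured. It differs from compound 1 by a group of 10 heavy atoms (5 carbon, 5 nitrogen; one six-membered aromatic ring with 2 hetero atoms) in place of a group of 10 heavy atoms (5 carbon, 5 nitrogen; one five-membered aromatic ring with 2 hetero atoms, one six-membered aromatic ring with 2 hetero atoms), on an amine nitrogen in a ring. Within the data shown here, no step between measured compounds is at hand, so the weight of this change is untested; compound 2 carries the same entering group on a different ring and in this assay compound 2 gives 1040 nM. The expected step is small, at most within the scatter: a 1.5-fold higher number from compound 1 to compound 3 (0.18 log units; within the scatter). Compound 3 is expected at 900 nM, in the range 300 nM to 2700 nM.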

Compound 3, half-maximal inhibitory concentration: 200 nM
Compound 3: the middle estimate sits 4.5-fold (0.65 log units) above what was measured; measured number below the stated range.
By their numbers in this assay, from the lowest: compound 3; then compounds 1 and 2 (each within the scatter of the next).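

On the amine nitrogen in the five-membered non-aromatic ring, the 2,6-diamino-5-cyanopyrimidin-4-yl group gives in this assay a 3.0-fold lower number from compound 1 to compound 3 (0.48 log units; beyond the scatter), so this position responds to the choice of group and the two-ring group that leaves is not needed for activity here. The entering and leaving groups have the same count of heavy atoms, so the step comes without a change in that count. No measurement at hand accounts for the step.

As far as these compounds go, whether the nitrile carries the step remains open, and a carboxamide or a chlorine in its place would test this. From the compounds shown here alone, the role of the ring's methyl group also remains open.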